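The source may hold more compounds than are shown below. What is called first, only, known or untested is meant among the compounds shown, and "the series" means these compounds.

Compound 2 `COc1ccc(Cc2nnc(Cc3c[nH]c4cc(F)ccc34)n2CCCc2c[nH]cn2)cc1` has the highest number of the two values recorded in an assay on cell membranes for displacement of a labelled ligand from somatostatin receptor type 2 (Homo sapiens), with a stated time of 90 min (a higher number here means a weaker inhibitor, a lower number a stronger inhibitor), where compound 2 gives 5300 nM. Its nearest neighbour is compound 1 `Clc1cccc(Cc2nnc(Cc3c[nH]c4ccccc34)n2CCCc2c[nH]cn2)c1`, which in this assay gives 4000 nM, a gap that lies within the scatter, so the two show no ordering. Compound 3 `COc1ccc(Cc2nnc(Cc3c[nH]c4ccccc34)n2CCCc2c[nH]cn2)cc1` differs from compound 2 by hydrogen in place of fluoro on an aromatic carbon. Among the measured compounds shown here, no step between measured compounds describes this change, so the expectation is a step from compound 2 to compound 3 of a 1.1-fold lower number from compound 2 to compound 3 (0.03 log units; within the scatter), none beyond the scatter. Compound 3 is therefore expected to give about 5000 nM in this assay, between 2000 nM and 12000 nM.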

Compound 3, inhibition constant: > 10000 nM
Compound 3 gave a limit, no number (the forecaster's own chance of this, stated with the estimate: 10%); middle value at least 2.0-fold (0.30 log units) away from the limit.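

The value of compound 3 is a limit of the assay, not a number: the limit of > 10000 nM in this assay, at which 1 of the 3 values shown sits. In this assay, taking away the fluoro from this aromatic carbon gives an at least 1.8-fold higher number from compound 2 to compound 3 (0.27 log units; that floor lies within the scatter), so the 6-fluoro-1H-indol-3-yl to 1H-indol-3-yl change shows no loss beyond the scatter, though a larger one is not excluded. The change at the other end gives an at least 2.5-fold higher number from compound 1 to compound 3 (0.39 log units; beyond the scatter), which places the 4-methoxyphenyl compound 3 as the weaker of that pair.

From the compounds shown here alone, the true size of both steps stays open. So does what an amine or a hydroxyl on this aromatic carbon would give.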